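This account rests on a few compounds, and the source may have more. Where it says the series, first, only, none or still open, it means among the compounds named here.

Three compounds share one core and differ only in the ring carried on the aromatic carbon para to the large group. Compound 1 `CCC(C)(C)Cc1c[nH]c(CCc2ccc(-c3ccncc3)cc2)n1` carries pyridin-4-yl there; in a functional assay on HEK293 cells for agonist activity at Bombesin receptor subtype-3 (Homo sapiens), read by luminescence and calcium flux, with a stated time of 10 min (a higher number here means that more compound is needed for the effect, a lower number that less compound is needed), compound 1 gives 305 nM, the highest of the three numbers. Compound 2 `CCC(C)(C)Cc1c[nH]c(CCc2ccc(-c3cccc(C#N)n3)cc2)n1` carries 6-cyanopyridin-2-yl and gives 193 nM, a change of a 1.6-fold lower number from compound 1 to compound 2 (0.20 log units; within the scatter), which stays within the scatter. Compound 3 `CCC(C)(C)Cc1c[nH]c(CCc2ccc(-c3cccc(N)n3)cc2)n1` carries 6-aminopyridin-2-yl and gives 37 nM, the step being an 8.2-fold lower number from compound 1 to compound 3 (0.92 log units; beyond the scatter); from compound 2 the step is a 5.2-fold lower number from compound 2 to compound 3 (0.72 log units; beyond the scatter).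

Compound 4 `CCC(C)(C)Cc1c[nH]c(CCc2ccc(N3CCCCC3)cc2)n1` is not yet measured. Compared with compound 1 the difference is piperidin-1-yl in place of pyridin-4-yl on an aromatic carbon. All three measured steps exchange one pyridyl group for another and keep the ring aromatic, so none of them tests the exchange of an aromatic ring for a non-aromatic one. Going by the values given here, the only step that is within the scatter, from compound 1 to compound 2, shows that changing the attached ring need not move the number much, while the other two show that it can move the number modestly. Among the compounds with values here, with no direct precedent, the expected step is a 1.3-fold higher number from compound 1 to compound 4 (0.12 log units; within the scatter), that is, no clear change beyond the scatter, with wide uncertainty. Compound 4 is therefore estimated at 400 nM, with a range from 120 nM to 1500 nM.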

Compound 4, half-maximal effective concentration: 171 nM
For compound 4 the middle estimate is 2.3-fold (0.37 log units) above the measured one, within the range that was stated.
By their numbers in this assay, from the lowest: compound 3; then compounds 4, 2 and 1 (each within the scatter of the next).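

Going by these compounds alone, this is the first step at this position that exchanges an aromatic ring for a non-aromatic one. In this assay, piperidin-1-yl in place of pyridin-4-yl gives a 1.8-fold lower number from compound 1 to compound 4 (0.25 log units; within the scatter), so for this pair, with the same count of heavy atoms in both groups, the loss of the aromatic ring produces no change beyond the scatter, and the comparison with the cyano-bearing ring, a 1.1-fold lower number from compound 2 to compound 4 (0.05 log units; within the scatter), agrees. Only compound 3 stands apart, with a 4.6-fold higher number from compound 3 to compound 4 (0.66 log units; beyond the scatter), which means that among the four compounds every step beyond the scatter involves compound 3, and no measurement shown offers an explanation for this.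

The compounds shown leave open whether an amino group needs an aromatic ring to bring the number down, which 4-aminopiperidin-1-yl in the same place could test against both compound 3 and compound 4. They also leave open how the unsubstituted pyridin-2-yl ring, or a carboxylic acid in place of the amino group on that ring, would compare with 6-aminopyridin-2-yl.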